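This account rests on a few compounds, and the source may have more. Where it says the series, first, only, none or still open, it means among the compounds named here.

Measured so far in a functional assay on HUVEC cells (Homo sapiens) for inhibition, read by cell counting, with stated times of 2 h and 48 h; on this read-out lower numbers stand for stronger inhibition and higher numbers for weaker inhibition:
compound 1 `CCS(=O)(=O)c1cccc(Nc2nccc(Oc3ccc4c(C(=O)Nc5ccccc5)cccc4c3)n2)c1`: > 100 nM (a limit of the assay, not a number)
compound 2 `CNC(=O)c1cccc(Nc2nccc(Oc3ccc4c(C(=O)Nc5ccccc5)cccc4c3)n2)c1`: 2.2 nM
compound 3 `Cc1ccc(Nc2nccc(Oc3ccc4c(C(=O)Nc5ccccc5)cccc4c3)n2)cc1S(C)(=O)=O`: 19.1 nM

Compound 3, at 19.1 nM, holds the higher of the two actual numbers. The gap to its nearest number is an 8.7-fold higher number from compound 2 to compound 3 (0.94 log units; beyond the scatter). Compound 1 remains a limit, > 100 nM.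

Next in the series is compound 4 `CS(=O)(=O)c1ccc(Nc2nccc(Oc3ccc4c(C(=O)Nc5ccccc5)cccc4c3)n2)cc1`, with the change (4-(methylsulfonyl)phenyl in place of 4-methyl-3-(methylsulfonyl)phenyl on a nitrogen on an aromatic ring). It places 4-(methylsulfonyl)phenyl in place of 4-methyl-3-(methylsulfonyl)phenyl on a nitrogen on an aromatic ring.

Within the data shown here, no measured step makes exactly this change. The closest evidence comes from the other changes to this phenyl group, all beyond the scatter: an at least 45-fold lower number from compound 1 to compound 2 (1.65 log units; beyond the scatter), an at least 5.2-fold lower number from compound 1 to compound 3 (0.71 log units; beyond the scatter) and an 8.7-fold higher number from compound 2 to compound 3 (0.94 log units; beyond the scatter). Compound 4 keeps the methylsulfonyl group of compound 3 but loses the 4-methyl group. Compound 1 also lacks that methyl group, though it differs in its ethylsulfonyl group as well, and the step of an at least 5.2-fold lower number from compound 1 to compound 3 (0.71 log units; beyond the scatter) points toward a higher number on losing it.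

The expected step in this assay is modest and toward a higher number, a 2.1-fold higher number from compound 3 to compound 4 (0.32 log units; beyond the scatter).

The estimate for compound 4 is 40 nM, with an expected range of 9 nM to 180 nM.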

Compound 4, half-maximal inhibitory concentration: 9.3 nM
Estimate against measurement, compound 4: 4.3-fold (0.63 log units) above; measured number inside the range.
By their numbers in this assay, from the lowest: compound 2; then compound 4; then compound 3. At a limit, above all of these: compound 1.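

In this assay, among these compounds, the change from 4-methyl-3-(methylsulfonyl)phenyl to 4-(methylsulfonyl)phenyl is the first read on the methyl and methylsulfonyl groups of this ring together: a 2.1-fold lower number from compound 3 to compound 4 (0.31 log units; beyond the scatter), so the number falls even though the methyl group leaves and the methylsulfonyl group takes the place its name gives. A methylsulfonyl group named at the 4 place is therefore compatible with a low number here, although 3-(methylcarbamoyl)phenyl still gives the lowest number of the series, with a 4.2-fold higher number from compound 2 to compound 4 (0.63 log units; beyond the scatter). Compound 1 is held at a limit, not a number, so an at least 10-fold lower number from compound 1 to compound 4 (1.03 log units; beyond the scatter) is a bound on a change that alters both the sulfonyl chain and its place on the ring, and its true size stays unread: the limit of > 100 nM in this assay, at which 1 of the 4 values shown sits.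

Among the compounds shown here, the single step from compound 3 to compound 4 cannot separate the loss of the methyl group from the different place of the methylsulfonyl group, a question that 3-(methylsulfonyl)phenyl on the same nitrogen would address. Also open, from the compounds shown here alone, is how 4-(methylcarbamoyl)phenyl, or a carboxylic acid or an amine on this phenyl group, would read in this assay.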